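Carbamate ester branch and maximal response in the series

The source may report more compounds than this note shows. Statements on the series, on what has been measured and on what is new or still open speak of the compounds shown alone.

For the measured compounds named here, compound 3 `Cc1nc(OC2CCN(C(=O)OC(C)(C)C)CC2)c2c(n1)N(c1ccc(S(C)(=O)=O)cc1F)CC2` gives 69% in a functional assay on CHO-K1 cells with Glucose-dependent insulinotropic receptor (Homo sapiens) as the target, read by a luciferase reporter, with a stated time of 5 h (a lower number here means a smaller maximal response, a higher number a larger maximal response), the lowest of the three numbers measured so far; compound 1 `CC(C)OC(=O)N1CCC(Oc2ncnc3c2CCN3c2ccc(S(C)(=O)=O)cc2F)CC1` gives 91% and compound 2 `CC(C)(C)OC(=O)N1CCC(Oc2ncnc3c2CCN3c2ccc(S(C)(=O)=O)cc2F)CC1` gives 139%. Compound 4 `Cc1nc(OC2CCN(C(=O)OC(C)C)CC2)c2c(n1)N(c1ccc(S(C)(=O)=O)cc1F)CC2` differs from compound 3 by hydrogen in place of methyl on a saturated chain carbon bound to an oxygen next to a carbonyl group and two saturated chain carbons. Going by the values given here, the step from compound 1 to compound 2 is this same change run in the opposite direction, and it was a number 48 percentage points higher from compound 1 to compound 2 (beyond the scatter); the only other step in the set, a number 70 percentage points lower from compound 2 to compound 3 (beyond the scatter), concerns the methyl on the aromatic carbon that compound 3 and compound 4 share. Reversing the first of these steps, the expected step is a number 44 percentage points lower from compound 3 to compound 4 (beyond the scatter), a large decrease. The estimated maximal response for compound 4 is 25%. The expected range for compound 4 runs from 5% to 55%.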

Compound 4, largest response reached (reported as percent of maximum), in percent of the reference or control that the assay uses: 45%
Estimate against measurement, compound 4: 20 percentage points below; measured number inside the range.
By their numbers in this assay, from the lowest: compound 4; then compound 3; then compound 1; then compound 2.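

Going from tert-butoxycarbonyl to isopropoxycarbonyl on the methyl-bearing core also lowers the maximal response, with the step reading a number 24 percentage points lower from compound 3 to compound 4 (beyond the scatter). The size of this change depends on the core in this assay: the same change on two cores in this assay, a number 48 percentage points higher (beyond the scatter) from compound 1 to compound 2 and a number 24 percentage points higher (beyond the scatter) from compound 4 to compound 3, 24 percentage points apart, beyond the scatter of two such steps

With isopropoxycarbonyl in place, methyl on the aromatic carbon also lowers the response, with the step reading a number 46 percentage points lower from compound 1 to compound 4 (beyond the scatter), but the size differs from that seen with tert-butoxycarbonyl: the same change on two cores in this assay, a number 70 percentage points lower (beyond the scatter) from compound 2 to compound 3 and a number 46 percentage points lower (beyond the scatter) from compound 1 to compound 4, 24 percentage points apart, beyond the scatter of two such steps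

Open, going by these compounds, is how a cyclopropyl or a longer chain in place of tert-butyl would behave on either core. Also open, on these data alone, is whether an amine in place of the methyl on the aromatic carbon would keep the response.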